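This account rests on a few compounds, and the source may have more. Where it says the series, first, only, none or still open, it means among the compounds named here.

Of the compounds shown here, three built on one shared core have been tested in a functional assay on A549 cells (Homo sapiens) for inhibition, read by CCK-8 assay, with a stated time of 72 h, tested at 10 uM; on this read-out lower numbers stand for less inhibition of growth and higher numbers for more inhibition of growth at the one concentration tested. Compound 1 `CN(C)C(=O)c1cc2cnc(Nc3ccc(NC(=O)C4(C(=O)Nc5cccc(C(F)(F)F)c5)CC4)cc3)nc2n1C1CCCC1` gives 89.2%, compound 2 `COC(=O)c1ccc(NC(=O)C2(C(=O)Nc3ccc(Nc4ncc5cc(C(=O)N(C)C)n(C6CCCC6)c5n4)cc3)CC2)cc1` gives 92%, and compound 3 `COc1ccc(NC(=O)C2(C(=O)Nc3ccc(Nc4ncc5cc(C(=O)N(C)C)n(C6CCCC6)c5n4)cc3)CC2)cc1` gives 78.5%, the lowest of the three, with the change a number 13.5 percentage points lower from compound 2 to compound 3 (beyond the scatter) and the change a number 10.7 percentage points lower from compound 1 to compound 3 (beyond the scatter) both beyond the scatter. Compound 4 `CN(C)C(=O)c1cc2cnc(Nc3ccc(NC(=O)C4(C(=O)Nc5ccc(C#N)cc5)CC4)cc3)nc2n1C1CCCC1` differs from compound 3 by cyano in place of methoxy on an aromatic carbon. Going by the values given here, the step from compound 2 to compound 3 is the one measured change at the same aromatic carbon, and it ran downward when methoxy entered; replacing methoxy again is therefore expected to move this assay upward by a number 8.5 percentage points higher from compound 3 to compound 4 (within the scatter), back toward the region of compound 1 and compound 2. Compound 4 is expected to give 87%, within 76% to 96%.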

Compound 4, percent growth inhibition at one concentration: 95%
For compound 4 the middle estimate is 8 percentage points below the measured one; the measured number falls inside the stated range.
By their numbers in this assay, from the lowest: compound 3; then compounds 1, 2 and 4 (each within the scatter of the next).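

In this assay, cyano in place of methoxy on this aromatic carbon gives a number 16.5 percentage points higher from compound 3 to compound 4 (beyond the scatter) and so shows that a replacement for methoxy can raise the number beyond the scatter. Cyano and methoxycarbonyl are not separated by a number 3 percentage points higher from compound 2 to compound 4 (within the scatter) and the 4-cyanophenyl and 3-(trifluoromethyl)phenyl groups are not separated by a number 5.8 percentage points higher from compound 1 to compound 4 (within the scatter), which leaves 4-methoxyphenyl as the only aryl group shown that stands apart. No measurement offered here accounts for this difference.

On these data alone, whether an amine or a carboxylic acid on this carbon would stay with compound 1, compound 2 and compound 4 or fall toward compound 3 remains open. A reading at one concentration also leaves open whether these three compounds would differ at lower concentrations.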